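Ring substituent change: nitro replaced by methyl

This account rests on a few compounds, and the source may have more. Where it says the series, first, only, none or still open, it means among the compounds named here.

For the measured compounds named here, in an ADME assay on HEL cells (Homo sapiens) for cytotoxicity, read by microscopy (on this read-out lower numbers stand for higher toxicity in this test and higher numbers for lower toxicity in this test), compound 2 `O=c1ccn(CCCCCOc2ccc([N+](=O)[O-])cc2)c(=O)[nH]1` gives 20000 nM, the lowest of the two numbers so far. Compound 1 `CC(C)(C)c1ccc(OCCCCCn2ccc(=O)[nH]c2=O)cc1` gives 100000 nM in this assay. Going by the values given here, the one measured step is a 5.0-fold lower number from compound 1 to compound 2 (0.70 log units; beyond the scatter). Compound 3 `Cc1ccc(OCCCCCn2ccc(=O)[nH]c2=O)cc1` is the next analogue; its change from compound 2 is methyl in place of nitro on an aromatic carbon. That step bears on it in reverse, since an alkyl group again occupies the position; because compound 1 with tert-butyl gives 100000 nM, the number is expected to move back upward, probably a modest rise. For compound 3 the expected step is a 3.0-fold higher number from compound 2 to compound 3 (0.48 log units; beyond the scatter), giving an estimate of 60000 nM within 20000 nM to 200000 nM.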

Compound 3, minimum cytotoxic concentration: 100000 nM
Beside the measured number, compound 3's estimate is 1.7-fold (0.22 log units) below it; the measured number falls inside the stated range.
By their numbers in this assay, from the lowest: compound 2; then compounds 1 and 3 (each within the scatter of the next).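

In this assay, replacing nitro with methyl gives a 5.0-fold higher number from compound 2 to compound 3 (0.70 log units; beyond the scatter), so among the three groups shown at this position, only nitro gives the lower number. The two alkyl groups do not separate, with methyl in place of tert-butyl giving no change at the digits printed from compound 1 to compound 3 (within the scatter). Nothing available explains why nitro stands apart from them. From the compounds shown here alone, whether an amine, a carboxylic acid or a nitrile at this position would track nitro or the alkyl groups remains open. So does whether a longer chain would shift the numbers of compound 2 and compound 3 alike.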